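The compounds below may be only part of what the source reports. "The series", "measured", "known", "first", "only" and "open" are said of these compounds alone.

The measured compounds and their values:
compound 1, `C/C=C/C(=O)Nc1cccc(-c2nc3ccccc3s2)c1`: > 25000 nM
compound 2, `O=C(O)/C=C/C(=O)Nc1cccc(-c2nc3ccccc3s2)c1`: > 25000 nM

In an ADME assay on HEK293 cells (Homo sapiens) for inhibition, with a stated time of 72 h (on this read-out lower numbers stand for an effect already at smaller amounts and higher numbers for an effect only at larger amounts of compound), compound 1 gives no number but only a limit, > 25000 nM. Compound 2 likewise gives only a limit, > 25000 nM. Within the data shown here, the single measured step, a step that the two limits leave unreadable from compound 1 to compound 2, therefore has no readable size, and its direction stays hidden because the limit of > 25000 nM in this assay, at which 2 of the 2 values shown sit, holds both values at the same edge of what this assay can report. Compound 1 thus stands at that edge and nowhere more exactly.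

Compound 3, `O=C(Nc1cccc(-c2nc3ccccc3s2)c1)c1cccnc1Cl`, is not yet measured. It differs from compound 1 by 2-chloropyridin-3-yl in place of prop-1-en-1-yl on a carbonyl carbon. Among the measured compounds shown here, no measured step bears on a change of this kind; the only step recorded, from compound 1 to compound 2, is itself unreadable. There is accordingly no measured ground for expecting compound 3 to move away from the edge where compound 1 sits, and the most likely outcome in this assay is once more a limit rather than a number.

For compound 3 the estimate is 30000 nM, with a range from 8000 nM to 100000 nM. This estimate means an expected step that the limit leaves unreadable from compound 1 to compound 3.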

Compound 3, half-maximal effective concentration: > 25000 nM
Compound 3 was reported as a limit (the forecaster's own chance of this, stated with the estimate: 75%); the middle value lies beyond the limit too.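

Compound 3 also gives only a limit in this assay, so its steps from compound 1 and from compound 2 cannot be read, and all three compounds remain at the same edge: the limit of > 25000 nM in this assay, at which 3 of the 3 values shown sit. The compounds shown leave open how far apart they truly lie, and whether any change on the carbonyl carbon brings a measurable effect.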